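Aryl exchange on a fused core: expected microsomal stability

The compounds below may be only part of what the source reports. "The series", "measured", "known", "first", "only" and "open" are said of these compounds alone.

Of the compounds shown here, three of a shared core have been measured in an ADME assay (liver) for metabolic stability, with Liver microsome (Homo sapiens) as the target, read by LC-MS, using microsomes, with a stated time of 30 min, tested at 4 uM; a higher number here means that more of the compound is left, a lower number that less of the compound is left. Compound 1 `Cc1nc(N2CCN(C)CC2)c2nc(-c3ccccc3Cl)n(CCO)c2n1` gives 13% in this assay, compound 2 `CCN1CCN(c2nc(C)nc3c2nc(-c2ccccc2Cl)n3CC2CCOCC2)CC1` gives 41%, and compound 3 `Cc1nc(N2CCN(C)CC2)c2nc(-c3ccccc3C(F)(F)F)n(C3CCOCC3)c2n1` gives 24%. Compound 3 therefore stands second highest of the three numbers: its nearest neighbour is compound 1, whose value lies lower by a margin beyond the scatter, and the furthest is compound 2, whose value lies higher, again beyond the scatter. No pair among these three differs in only one place, so no single step can be read from them.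

Compound 4 `COc1ccc(-c2nc3c(N4CCN(C)CC4)nc(C)nc3n2C2CCOCC2)c(C)c1` has not yet been measured. Compared with compound 3, it carries 4-methoxy-2-methylphenyl in place of 2-(trifluoromethyl)phenyl on an aromatic carbon. The fused core, the oxan-4-yl group and the methylpiperazine are kept unchanged.

Going by the values given here, the measured set offers no step that isolates an exchange of the aryl group. The expectation for compound 4 therefore rests on the value of compound 3, 24%, as the anchor. The step from compound 3 to compound 4 is estimated at a number 6 percentage points lower from compound 3 to compound 4 (within the scatter), a modest move downward that may not exceed the scatter. Compound 4 is accordingly expected to give about 18% in this assay, most likely between 6% and 34%.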

Compound 4, percent of the compound remaining: 21%
For compound 4 the middle estimate is 3 percentage points below the measured one; the range from low to high includes it.
By their numbers in this assay, from the lowest: compounds 1, 4 and 3 (each within the scatter of the next, the first and the last beyond it); then compound 2.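

In this assay, going by these compounds alone, the exchange of 2-(trifluoromethyl)phenyl for 4-methoxy-2-methylphenyl, on the aromatic carbon between two ring nitrogen atoms, gives a number 3 percentage points lower from compound 3 to compound 4 (within the scatter) and is the first step in the set that can be read at one place. With the oxan-4-yl group and the methylpiperazine kept, this aryl position takes an exchange of three fluorine atoms for one oxygen atom, a hydrogen-bond acceptor, and the two compounds are not separated beyond the usual scatter of this read-out. The data at hand offer nothing that would explain this outcome.

A single exchange cannot show how far this tolerance extends, so a plain phenyl, a pyridine ring or an aryl group carrying a carboxylic acid or a morpholine could still behave differently at this carbon. Steps at the other places, the group on the piperazine and the group on the ring nitrogen, cannot be read from these compounds, so the share of each place in the values of the series remains open.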